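Amide nitrogen substituent variation on the shared core

The source may report more compounds than this note shows. Statements on the series, on what has been measured and on what is new or still open speak of the compounds shown alone.

Measured so far in a functional assay on HeLa cells (Homo sapiens) for cytotoxicity, read by MTT assay, with a stated time of 72 h; a lower number here means a stronger inhibitor, a higher number a weaker inhibitor:
compound 1 `CCN(CC)c1ccc2cc(C(=O)NCCO)c(=O)oc2c1` gives > 100000 nM, a limit of the assay.
compound 2 `CCN(CC)c1ccc2cc(C(=O)NO)c(=O)oc2c1` gives 35900 nM.

Within the data shown here, compound 2 holds the only number in this assay; the other value is a limit, with the limit of > 100000 nM in this assay, at which 1 of the 2 values shown sits, as the only evidence on that side. Among the measured compounds shown here, the one measured step, an at least 2.7-fold lower number from compound 1 to compound 2 (0.44 log units; beyond the scatter), was the exchange of groups on the same amide-type nitrogen and is the sole guide for the next compound.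

Compound 3 `CCN(CC)c1ccc2cc(C(=O)N/N=C(/C)c3cccs3)c(=O)oc2c1` differs from compound 2 by a group of 8 heavy atoms (6 carbon, 1 nitrogen, 1 sulfur; one five-membered aromatic ring with 1 hetero atom) in place of one oxygen atom, on an amide-type nitrogen. For the measured compounds named here, no measured step involves a group of this kind, so the direction is open. The prior step shows that changes at this nitrogen can move the number beyond the scatter, but a larger, donor-free entering group is not covered. Compound 3 is therefore expected near 50000 nM, within 10000 nM to 200000 nM. This corresponds to an expected 1.4-fold higher number from compound 2 to compound 3 (0.14 log units; within the scatter), with a real chance that only a limit is reported.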

Compound 3, half-maximal inhibitory concentration: > 100000 nM
Compound 3 ended at the assay's limit (the forecaster's own chance of this, stated with the estimate: 35%); middle value at least 2.0-fold (0.30 log units) away from the limit.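

On the amide-type nitrogen, exchanging hydroxy for the group of 8 heavy atoms with its five-membered aromatic ring gives an at least 2.7-fold higher number from compound 2 to compound 3 (0.44 log units; beyond the scatter), so a second replacement of hydroxy on this nitrogen also ends at a limit of the assay. The step between compound 1 and compound 3 cannot be read, as both values are limits, and no order can be stated between the 2-hydroxyethyl group and the group in compound 3. Compound 2 therefore remains the only compound with a number in this assay, and most of the evidence at this position consists of: the limit of > 100000 nM in this assay, at which 2 of the 3 values shown sit.

On these data alone, whether the hydroxy group itself is needed for a measurable number remains open. Methoxy, an amine or a short chain ending in a carboxylic acid on this nitrogen would address that question.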